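This account rests on a few compounds, and the source may have more. Where it says the series, first, only, none or still open, it means among the compounds named here.

Measured compounds:
- compound 1, `C[C@H]1[C@H](NCc2cncs2)C[C@H]2C[C@@H]1C2(C)C`: > 100000 nM
- compound 2, `C[C@H]1[C@H](NCc2cc(Br)cs2)C[C@H]2C[C@@H]1C2(C)C`: 6250 nM
- compound 3, `C[C@H]1[C@H](NCc2ccsc2)C[C@H]2C[C@@H]1C2(C)C`: 50000 nM

In an ADME assay on MDCK cells (Canis lupus familiaris) for cytotoxicity, read by microscopy, with a stated time of 48 h (a lower number here means that less compound is tolerated, a higher number that more compound is tolerated), compound 1 gives > 100000 nM, which is a limit of the assay rather than a number. Among the two numbers actually reported, compound 3 has the higher one; the nearest is compound 2, and the step of an 8.0-fold higher number from compound 2 to compound 3 (0.90 log units; beyond the scatter) is a modest change beyond the scatter. Compound 4, `Cc1n[nH]cc1CN[C@@H]1C[C@H]2C[C@@H]([C@H]1C)C2(C)C`, has not been tested yet. It differs from compound 3 in one place: 3-methyl-1H-pyrazol-4-yl in place of thiophen-3-yl on a saturated chain carbon bound to an amine nitrogen.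

Among the compounds with values here, two measured steps bear on this change, both swaps of the aromatic ring at the same place. The step of an 8.0-fold higher number from compound 2 to compound 3 (0.90 log units; beyond the scatter) was modest. The step of an at least 2.0-fold lower number from compound 1 to compound 3 (0.30 log units; that floor lies within the scatter) stays within the scatter, and compound 1 sits at a limit (the limit of > 100000 nM in this assay, at which 1 of the 3 values shown sits), so its true distance from compound 3 is not known. Ring swaps here have therefore moved the number by a modest amount or not at all. For compound 4, a step of a 2.0-fold higher number from compound 3 to compound 4 (0.30 log units; within the scatter) is expected, toward more compound being tolerated, though a reading at the limit is possible. Compound 4 is estimated at 100000 nM, with a range from 25000 nM to 400000 nM.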

Compound 4, minimum cytotoxic concentration: > 100000 nM
Compound 4 ended at the assay's limit; the forecaster's own chance of this, stated with the estimate: 40%; the middle value sits exactly at the limit.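

In this assay, compound 4 shows that the place on a saturated chain carbon bound to an amine nitrogen takes 3-methyl-1H-pyrazol-4-yl and still reads at a limit, as 1,3-thiazol-5-yl does in compound 1. Against thiophen-3-yl the change is an at least 2.0-fold higher number from compound 3 to compound 4 (0.30 log units; that floor lies within the scatter), so this step alone does not separate the two rings. Against 4-bromothiophen-2-yl it is an at least 16-fold higher number from compound 2 to compound 4 (1.20 log units; beyond the scatter), which leaves compound 2 with the lowest number, its steps to all three other compounds lying beyond the scatter.

From the compounds shown here alone, the step between compound 1 and compound 4 cannot be read, and how much more of either compound would be tolerated stays unknown: the limit of > 100000 nM in this assay, at which 2 of the 4 values shown sit. Also open is how the number would respond to a carboxylic acid or a longer chain at this place.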